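The compounds below may be only part of what the source reports. "The series", "measured", "known", "first", "only" and "open" are said of these compounds alone.

Measured compounds and their values in a functional assay on A549 cells (Homo sapiens) for inhibition, read by colorimetric assay and MTT assay, with a stated time of 72 h; a lower number here means a stronger inhibitor, a higher number a weaker inhibitor:
compound 1, `C=CCCCCOc1cc2ccccc2cc1-c1cnc(OCCC=C)n1C`: 21000 nM
compound 2, `C=CCCCCOc1cc2ccccc2cc1-c1cnc(OCCCCC=C)n1C`: 16000 nM
compound 3, `C=CCCOc1ncc(-c2ccccc2OC)n1C`: 22000 nM

Compound 1 and compound 2 share one core and differ in a single place: but-3-en-1-yl in place of vinyl on a saturated chain carbon, two bonds along the chain from an oxygen on an aromatic ring. This change gave a 1.3-fold lower number from compound 1 to compound 2 (0.12 log units; within the scatter). Compound 3 rests on a different core; the difference between the two cores is not broken down here. Its value and those of compound 1 and compound 2 all lie within the scatter of one another, so no order among the three can be read from them.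

Compound 4, `C=CCCCCOc1ncc(-c2ccccc2OC)n1C`, has not yet been measured. It arises from compound 3 by the same change as that from compound 1 to compound 2: but-3-en-1-yl in place of vinyl on a saturated chain carbon, two bonds along the chain from an oxygen on an aromatic ring. Because the step of a 1.3-fold lower number from compound 1 to compound 2 (0.12 log units; within the scatter) was small, a step of similar size is expected here, a 1.3-fold lower number from compound 3 to compound 4 (0.11 log units; within the scatter). Compound 4 is estimated at 17000 nM, with a likely range from 8000 nM to 40000 nM.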

Compound 4, half-maximal inhibitory concentration: 5000 nM
Compound 4: middle estimate off by 3.4-fold (0.53 log units), on the high side; the whole stated range lies above it.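

In this assay, replacing (but-3-en-1-yl)oxy with (hex-5-en-1-yl)oxy gave a 4.4-fold lower number from compound 3 to compound 4 (0.64 log units; beyond the scatter), a step beyond the scatter, whereas the same change on the core of compound 1 stayed within it. Among the compounds shown here, the size of this step therefore did not carry over from one core to the other: the same change on two cores in this assay, a 1.3-fold lower number (0.12 log units; within the scatter) from compound 1 to compound 2 and a 4.4-fold lower number (0.64 log units; beyond the scatter) from compound 3 to compound 4, 3.4-fold (0.53 log units) apart, beyond the scatter of two such steps With only two cores compared, this shows that the step depends on the core in these two pairs, but it does not show which feature of the cores is responsible, nor does it give a rule for any further core.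

The compounds shown leave open whether a longer chain on the oxygen would lower the number further on the core of compound 3. They also leave open whether the terminal double bond matters, which a saturated hexyl chain or a chain ending in an amine could test.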